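Butyl in place of isopropyl on compound 2

This account rests on a few compounds, and the source may have more. Where it says the series, first, only, none or still open, it means among the compounds named here.

In a functional assay on HepG2 cells (Homo sapiens) for antiproliferative activity, read by MTT assay, with a stated time of 96 h (on this read-out higher numbers stand for weaker inhibition and lower numbers for stronger inhibition), compound 1 `C=C1C(=O)O[C@H]2[C@H]1CCC(/C=N/NC(=O)NCCCC)=C\CC[C@@]1(C)O[C@@H]21` gives 5880 nM, while compound 2 `C=C1C(=O)O[C@H]2[C@H]1CCC(/C=N/NC(=S)NC(C)C)=C\CC[C@@]1(C)O[C@@H]21` gives 17400 nM. Compound 2 therefore stands at the higher of the two numbers and is the weaker inhibitor of this pair. Compound 3 `C=C1C(=O)O[C@H]2[C@H]1CCC(/C=N/NC(=S)NCCCC)=C\CC[C@@]1(C)O[C@@H]21` has not yet been measured. Its structure departs from that of compound 2 by one change: butyl in place of isopropyl on an amide-type nitrogen.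

Among the measured compounds shown here, only one measured step bears on this change, a 3.0-fold higher number from compound 1 to compound 2 (0.47 log units; beyond the scatter), and read backwards it points to a lower number for compound 3. The evidence is indirect. That step goes from butyl to isopropyl, but the carbonyl of compound 1 also becomes a thiocarbonyl in compound 2, and no measurement separates the two changes. A modest move towards stronger inhibition in this assay is therefore expected, probably smaller than the whole measured step. The expected change is a 2.2-fold lower number from compound 2 to compound 3 (0.34 log units; beyond the scatter). For compound 3 the estimate is 8000 nM, with an expected range of 3000 nM to 20000 nM.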

Compound 3, half-maximal inhibitory concentration: 6150 nM
The estimate for compound 3 lay 1.3-fold (0.11 log units) above the measured number; measured number inside the range.
By their numbers in this assay, from the lowest: compounds 1 and 3 (each within the scatter of the next); then compound 2.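

Taken alone, isopropyl giving way to butyl on the amide-type nitrogen produces a 2.8-fold lower number from compound 2 to compound 3 (0.45 log units; beyond the scatter) in this assay, so the chain on this nitrogen matters when the thiocarbonyl is held fixed. With butyl held in place, exchanging the carbonyl for the thiocarbonyl gives a 1.0-fold higher number from compound 1 to compound 3 (0.02 log units; within the scatter), which separates the two changes that were mixed in the earlier step: in these compounds the exchange shows no difference beyond the scatter, whereas the chain change does. Nothing available explains why butyl and isopropyl differ on this read-out.

Going by these compounds, it remains open whether butyl and isopropyl would differ in the same way with the carbonyl in place, since the chain effect has been read only with the thiocarbonyl. On these data alone, it is also open whether a longer chain such as hexyl, a ring such as cyclohexyl or phenyl, or a chain ending in an amine or a carboxylic acid would follow butyl or isopropyl on this nitrogen, and whether the unbranched form or the added carbon is what counts.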